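Swapping the aryl ketone group in compound 3

The source may report more compounds than this note shows. Statements on the series, on what has been measured and on what is new or still open speak of the compounds shown alone.

Compound 1 `COc1ccc(/C=C/c2cc(OC)cc(OC)c2/C=C/C(=O)c2cccc(OC)c2)cc1`: 11.6 ug/mL
Compound 2 `CCCCCCOc1ccc(C(=O)/C=C/c2c(/C=C/c3ccc(OC)cc3)cc(OC)cc2OC)cc1`: 16.2 ug/mL
Compound 3 `COc1ccc(/C=C/c2cc(OC)cc(OC)c2/C=C/C(=O)c2cccc(Cl)c2)cc1`: 9.5 ug/mL

All three values come from a functional assay on HepG2 cells (Homo sapiens) for antiproliferative activity, read by MTT assay, with a stated time of 48 h (on this read-out higher numbers stand for weaker inhibition and lower numbers for stronger inhibition), and they lie within the scatter of one another. Compound 3, at 9.5 ug/mL, therefore cannot be separated from compound 1 or compound 2 on these numbers.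

Compound 4 `COc1ccc(/C=C/c2cc(OC)cc(OC)c2/C=C/C(=O)c2ccccc2C)cc1` has not yet been measured in this assay. It differs from compound 3 by one change: 2-methylphenyl in place of 3-chlorophenyl on a carbonyl carbon. In words, this is 2-methylphenyl in place of 3-chlorophenyl on a carbonyl carbon.

Among the compounds with values here, only one measured step bears on this change: a 1.2-fold lower number from compound 1 to compound 3 (0.09 log units; within the scatter). That step, chloro in place of methoxy on an aromatic carbon, stayed within the scatter. Within the data shown here, no measured compound carries the 2-methylphenyl group, so the evidence is indirect, and no step beyond the scatter is expected in either direction.

The expected step is a 1.2-fold higher number from compound 3 to compound 4 (0.06 log units; within the scatter).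

For compound 4 the estimated value is 11 ug/mL, with an expected range of 5.5 ug/mL to 22 ug/mL.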

Compound 4, half-maximal inhibitory concentration: 5.3 ug/mL
Beside the measured number, compound 4's estimate is 2.1-fold (0.32 log units) above it; measured number below the stated range.
By their numbers in this assay, from the lowest: compounds 4, 3, 1 and 2 (each within the scatter of the next, the first and the last beyond it).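

In this assay, the aryl group on the carbonyl carbon now produces a step that clears the scatter: 2-methylphenyl in place of 3-methoxyphenyl gives a 2.2-fold lower number from compound 1 to compound 4 (0.34 log units; beyond the scatter), a modest change. The same group in place of 3-chlorophenyl gives a 1.8-fold lower number from compound 3 to compound 4 (0.25 log units; within the scatter), so the exchange of aryl groups separates only the 3-methoxyphenyl and 2-methylphenyl members of this set. Nothing among the available data explains this difference.

The compounds shown leave open whether the step follows the methyl group itself or its location on the ring, a question that 3-methylphenyl and 2-chlorophenyl would address. On these data alone, how an aryl group carrying an amine or a carboxylic acid would read on this carbonyl carbon also remains open.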